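The source may hold more compounds than are shown below. What is called first, only, known or untested is meant among the compounds shown, and "the series" means these compounds.

Measured so far:
Compound 1 `COc1ccc(S(=O)(=O)Nc2ccc(C(=O)CSC(C)=O)cn2)cc1` gives 540 nM in a functional assay on HCT-116 cells (Homo sapiens) for cytotoxicity; a higher number here means that more compound is needed for the effect, a lower number that less compound is needed.
Compound 2 `CC(=O)SCC(=O)c1ccc(NS(=O)(=O)c2ccc(OCCCN3CCCC3)cc2)nc1` gives 820 nM in this assay.

Going by the values given here, compound 2 holds the higher of the two numbers, but its only neighbour lies close: the step of a 1.5-fold higher number from compound 1 to compound 2 (0.18 log units; within the scatter) stays within the scatter, so the two compounds cannot be ordered on these data. The next compound, compound 3 `COCCCOc1ccc(S(=O)(=O)Nc2ccc(C(=O)CSC(C)=O)cn2)cc1`, differs from compound 2 in one place: methoxy in place of pyrrolidin-1-yl on a saturated chain carbon, three bonds along the chain from an oxygen on an aromatic ring. Among the compounds with values here, only one measured step bears on this change, the step of a 1.5-fold higher number from compound 1 to compound 2 (0.18 log units; within the scatter), in which the same part of the chain on the oxygen of the aromatic ring was altered and the number in this assay moved by no more than the scatter. On that single step, the group at the far end of this chain seems to matter little here, though two compounds are a thin basis for that view. He therefore expects compound 3 to show no step beyond the scatter, a 1.3-fold lower number from compound 2 to compound 3 (0.10 log units; within the scatter), and estimates for compound 3 a value of 650 nM, with a range from 300 nM to 1500 nM.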

Compound 3, half-maximal effective concentration: 5300 nM
Estimate against measurement, compound 3: 8.2-fold (0.91 log units) below; measured number above the stated range.
By their numbers in this assay, from the lowest: compounds 1 and 2 (each within the scatter of the next); then compound 3.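

The far end of this chain matters after all in this assay. Methoxy in place of pyrrolidin-1-yl, on a saturated chain carbon three bonds along the chain from an oxygen on an aromatic ring, gives a 6.5-fold higher number from compound 2 to compound 3 (0.81 log units; beyond the scatter), which shows that the earlier step, a 1.5-fold higher number from compound 1 to compound 2 (0.18 log units; within the scatter), did not mean that this position accepts any end group. Compound 3 also separates from the unextended methoxy compound, with a 9.8-fold higher number from compound 1 to compound 3 (0.99 log units; beyond the scatter), so among these compounds the number stays within the scatter of compound 1 with the 3-(pyrrolidin-1-yl)propyl chain but not with the 3-methoxypropyl chain, and nothing shown here accounts for that difference.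

The compounds shown leave open whether the pyrrolidine ring itself is needed or whether an open-chain amine such as dimethylamino, or another ring amine such as piperidine or morpholine, at the end of the same chain would give a number like that of compound 2. They also leave open whether a hydroxyl in place of methoxy, or a shorter ethyl chain carrying either end group, would behave like compound 3 or like compound 2.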